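The source may report more compounds than this note shows. Statements on the series, on what has been measured and on what is new or still open speak of the compounds shown alone.

Going by the values given here, compound 2 `O=C(Nc1cccc(-c2oc3cc(-c4ccc(F)cc4)ccc3c(=O)c2O)c1)c1ccc(Cl)nc1` is one of only two compounds measured so far in a functional assay on HCC1937 cells (Homo sapiens) for antiproliferative activity, read by CCK-8 assay, with a stated time of 72 h (a higher number here means a weaker inhibitor, a lower number a stronger inhibitor), where compound 2 gives 7550 nM. Compound 1 `Cc1ccccc1C(=O)Nc1cccc(-c2oc3cc(-c4ccc(F)cc4)ccc3c(=O)c2O)c1` gives 9900 nM in this assay, and the step of a 1.3-fold lower number from compound 1 to compound 2 (0.12 log units; within the scatter) means the two cannot be told apart. Compound 3 `O=C(Nc1cccc(-c2oc3cc(-c4ccc(F)cc4)ccc3c(=O)c2O)c1)c1cc(F)cc(F)c1` differs from compound 2 by 3,5-difluorophenyl in place of 6-chloropyridin-3-yl on a carbonyl carbon. Among the compounds with values here, the only measured step that bears on exchanging the aryl group on this carbonyl carbon is a 1.3-fold lower number from compound 1 to compound 2 (0.12 log units; within the scatter), which stayed inside the scatter, so no shift beyond the scatter is expected here either. Compound 3 is therefore expected to give 8000 nM, in the range 4000 nM to 16000 nM. That expectation amounts to a step of a 1.1-fold higher number from compound 2 to compound 3 (0.03 log units; within the scatter).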

Compound 3, half-maximal inhibitory concentration: 2070 nM
Compound 3: the middle estimate sits 3.9-fold (0.59 log units) above what was measured; the measured number lies below the stated range.
By their numbers in this assay, from the lowest: compound 3; then compounds 2 and 1 (each within the scatter of the next).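

In this assay the aryl group on this carbonyl carbon turns out to matter, with a 3.6-fold lower number from compound 2 to compound 3 (0.56 log units; beyond the scatter) and a 4.8-fold lower number from compound 1 to compound 3 (0.68 log units; beyond the scatter) as steps that both leave the scatter, which the earlier exchange did not. The 3,5-difluorophenyl group thus stands apart from the 6-chloropyridin-3-yl and 2-methylphenyl groups, though only modestly. Nothing measured here explains this difference. Still open, as far as these compounds go, is whether a plain phenyl or a 3-fluorophenyl group would match 3,5-difluorophenyl, and what a group carrying an amine or a carboxylic acid would give at this position.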